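Removing the sulfate from a sugar amide: expected loss

A few compounds are considered here, and "the series" means these few. Any claim that something is new, unique, unknown or untested is made for them only; others in the source may bear on it.

Of the compounds shown here, two have been tested in a functional assay on U-373MG ATCC cells (Homo sapiens), read by thymidine incorporation; a higher number here means a weaker inhibitor, a lower number a stronger inhibitor. Compound 1 `CCCCCCCCCCCCCCCCO[C@H]1O[C@H](CO)[C@@H](O)[C@H](O)[C@H]1NC(C)=O` gives > 50 uM, a limit of the assay rather than a number. Among the compounds with values here, compound 2 `CCCCC(=O)N[C@H]1[C@@H](OCCc2ccccc2)O[C@H](COCC(CO)(CO)COS(=O)(=O)O)[C@@H](O)[C@@H]1O` gives 6.7 uM, the only numerical value so far; the other result sits at the limit of > 50 uM in this assay, at which 1 of the 2 values shown sits. Compound 3 `CCCCC(=O)N[C@H]1[C@@H](OCCc2ccccc2)O[C@H](COCC(CO)(CO)CO)[C@@H](O)[C@@H]1O` differs from compound 2 by hydrogen in place of sulfo on an oxygen on a saturated carbon. Within the data shown here, with no measured step to lean on, a weakening beyond the scatter is expected, as a 3.7-fold higher number from compound 2 to compound 3 (0.57 log units; beyond the scatter). Compound 3 is estimated at 25 uM, between 8 uM and 80 uM.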

Compound 3, concentration for 50% inhibition: > 50 uM
Compound 3 was reported as a limit; the forecaster's own chance of this, stated with the estimate: 35%; middle value at least 2.0-fold (0.30 log units) away from the limit.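

In this assay, changing sulfooxy to hydroxy on this oxygen gives an at least 7.4-fold higher number from compound 2 to compound 3 (0.87 log units; beyond the scatter), so the sulfo group is needed for the activity seen with compound 2. Compound 3 gives > 50 uM, which is a limit and not a number. The true size of the loss cannot be read because the result for compound 3 stops at that limit: the limit of > 50 uM in this assay, at which 2 of the 3 values shown sit.

Still open, on these data alone, is whether a different group on this oxygen, such as a phosphate or a carboxylic acid, could stand in for the sulfo group and restore inhibition.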